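Two Diterpenoids Against Colon Cancer Cells

This account rests on a few compounds, and the source may have more. Where it says the series, first, only, none or still open, it means among the compounds named here.

Compound 1 `C=CC(=C)CC[C@@H]1[C@@]2(C)CCC[C@](C)(COC(=O)/C=C/c3ccc(O)cc3)[C@@H]2CC[C@@]1(C)O` gives 19300 nM in a functional assay on SW480 cells (Homo sapiens) for cytotoxicity, read by MTT assay, with a stated time of 48 h; on this read-out lower numbers stand for stronger inhibition and higher numbers for weaker inhibition. Compound 2 `C=C1CC[C@@H]2[C@](C)(CCC[C@]2(C)C(=O)O)[C@H]1CC/C(C)=C/CO` returns only a limit, > 40000 nM, in this assay; among the two numbers shown it is the one that sits at that limit (the limit of > 40000 nM in this assay, at which 1 of the 2 values shown sits). Compound 3 `C=CC(=C)[C@@H](O)C[C@H]1C(=C)CC[C@@H]2[C@]1(C)CCC[C@]2(C)C(=O)O` differs from compound 2 by a group of 6 heavy atoms (5 carbon, 1 oxygen; no ring) in place of a group of 6 heavy atoms (5 carbon, 1 oxygen; no ring), on a saturated chain carbon bound to a saturated ring carbon. Going by the values given here, no measured pair covers this change, so the author expects compound 3 to stay close to compound 2, with a step of an at least 1.1-fold lower number from compound 2 to compound 3 (0.05 log units; that floor lies within the scatter) that is not expected to exceed the scatter. Compound 3 is estimated at 35000 nM, ranging from 15000 nM to 80000 nM.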

Compound 3, half-maximal inhibitory concentration: > 40000 nM
Compound 3 gave a limit, no number; the forecaster's own chance of this, stated with the estimate: 50%; middle value at least 1.1-fold (0.05 log units) away from the limit.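

Compound 2 and compound 3 both sit at a limit in this assay, so no step can be read between them: the limit of > 40000 nM in this assay, at which 2 of the 3 values shown sit.

On these data alone, whether replacing the 4-hydroxy-2-methylbut-2-en-1-yl group shifts the read-out at all stays open.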